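Hydroxy to methoxy on a ring oxygen

The source may report more compounds than this note shows. Statements on the series, on what has been measured and on what is new or still open speak of the compounds shown alone.

- compound 1 `COc1ccc(/C=C2\Cc3c(cc(OC)c(OC)c3OC)C2=O)cc1` gives 273 nM
- compound 2 `COc1ccc(/C=C2\Cc3c(cc(OC)c(OC)c3OC)C2=O)cc1OC` gives 9740 nM
- compound 3 `COc1cc2c(cc1O)C(=O)/C(=C/c1ccc(OC)c(OC)c1OC)C2` gives 3420 nM

All three numbers come from a functional assay on A549 cells (Homo sapiens) for antiproliferative activity, read by MTT assay, with a stated time of 48 h; a higher number here means a weaker inhibitor of growth, a lower number a stronger inhibitor of growth. Compound 3 stands in the middle. The number is higher for compound 2, at 9740 nM, and lower for compound 1, at 273 nM, and both gaps are beyond the usual scatter.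

The next structure is compound 4 `COc1cc2c(cc1OC)C(=O)/C(=C/c1ccc(OC)c(OC)c1OC)C2`, which is compound 3 with one small change: methyl in place of hydrogen on an oxygen on an aromatic ring. In other words, a hydroxy becomes a methoxy.

Among the measured compounds shown here, no measured pair shows this exact change. The nearest evidence is a 36-fold higher number from compound 1 to compound 2 (1.55 log units; beyond the scatter), a large step. That step also brings in a methoxy, but there it takes the place of hydrogen on an aromatic carbon, so it is a different change and gives no reliable direction for this one. Its size does argue for caution, since one small edit in this set moved the number a long way. In this assay, no clear shift is therefore expected, only a wide range of uncertainty.

The estimated change is a 1.2-fold higher number from compound 3 to compound 4 (0.07 log units; within the scatter).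

For compound 4 the expected value is 4000 nM, with an estimated range from 800 nM to 15000 nM.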

Compound 4, concentration for 50% growth inhibition: > 10000 nM
Compound 4 gave a limit, no number; the forecaster's own chance of this, stated with the estimate: 3%; middle value at least 2.5-fold (0.39 log units) away from the limit.
By their numbers in this assay, from the lowest: compound 1; then compound 3; then compound 2. At a limit, above all of these: compound 4.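

Among the compounds shown here, this is the first direct reading of hydroxy to methoxy at this place, on an oxygen on an aromatic ring, and in this assay the result is an at least 2.9-fold higher number from compound 3 to compound 4 (0.46 log units; beyond the scatter). In this one pair, then, adding a single methyl to that oxygen weakens growth inhibition, something the earlier step could not show, as its methoxy replaced a hydrogen on an aromatic carbon. The full size of the new step remains unknown, since compound 4 gave only a limit and no number: the limit of > 10000 nM in this assay, at which 1 of the 4 values shown sits.

The compounds shown leave open how an ethoxy group, a longer chain on the same oxygen, or an amine in place of the hydroxy would read, and so whether the hydroxy itself matters or only the methyl is poorly accepted. They also leave open whether the same change would give a similar step in a compound with another arrangement of methoxy groups around the shared core, as a single pair cannot establish a general rule.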